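Swapping dichlorophenyl for methoxyphenyl on a symmetric core

A few compounds are considered here, and "the series" means these few. Any claim that something is new, unique, unknown or untested is made for them only; others in the source may bear on it.

Measured so far:
- compound 1 `C=CCn1c(=O)/c(=C\c2cccc(Cl)c2)[nH]c(=O)/c1=C\c1ccccc1OC`: 5200 nM
- compound 2 `COc1ccccc1/C=c1/[nH]c(=O)/c(=C\c2cccc(Cl)c2Cl)[nH]c1=O`: "not active" (no number reported)
- compound 3 `C=CCn1c(=O)/c(=C\c2cccc(Cl)c2Cl)[nH]c(=O)/c1=C\c1ccccc1OC`: 2300 nM

In a functional assay on A549 cells (Homo sapiens) for cytotoxicity, read by CCK-8 assay, with a stated time of 72 h (a lower number here means a stronger inhibitor, a higher number a weaker inhibitor), compound 3 gives 2300 nM, the lowest of the two numbers available; the nearest is compound 1, which in this assay gives 5200 nM. Compound 2, which lacks the allyl group of the other two, is reported as "not active" (no number reported) without a number.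

Compound 4 `C=CCn1c(=O)/c(=C\c2ccccc2OC)[nH]c(=O)/c1=C\c1ccccc1OC` is the next structure: 2-methoxyphenyl in place of 2,3-dichlorophenyl on a double-bonded chain carbon bound to an aromatic carbon. The result is a molecule carrying the same 2-methoxyphenyl group on both double-bonded chain carbons.

Among the compounds with values here, only one measured step speaks to this change, and only in part: a 2.3-fold lower number from compound 1 to compound 3 (0.35 log units; beyond the scatter). That step added a single chlorine, whereas the move to compound 4 removes both chlorines and brings in a methoxy group, for which no measured comparison exists. Undoing the chlorine addition points toward a higher number, and the methoxy group is an unknown. The expected step is a 3.5-fold higher number from compound 3 to compound 4 (0.54 log units; beyond the scatter), a weaker inhibitor, with wide uncertainty. Compound 4 is expected to give about 8000 nM in this assay, between 3000 nM and 25000 nM.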

Compound 4, half-maximal inhibitory concentration: 22400 nM
For compound 4 the middle estimate is 2.8-fold (0.45 log units) below the measured one, and the stated range covers the measured number.
By their numbers in this assay, from the lowest: compound 3; then compound 1; then compound 4.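

In this assay, within the data shown here, the earlier compounds varied only the chlorine count on the ring at this place, whereas 2-methoxyphenyl in place of 2,3-dichlorophenyl on a double-bonded chain carbon bound to an aromatic carbon gives a 9.7-fold higher number from compound 3 to compound 4 (0.99 log units; beyond the scatter) and 2-methoxyphenyl in place of 3-chlorophenyl gives a 4.3-fold higher number from compound 1 to compound 4 (0.63 log units; beyond the scatter). Among these three compounds, both chlorine-bearing groups therefore go with lower numbers than 2-methoxyphenyl, and the choice of ring substituent here can move the number further than the single added chlorine did in a 2.3-fold lower number from compound 1 to compound 3 (0.35 log units; beyond the scatter) on its own. The data shown offer no measurement that would explain these steps.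

Each new step removes chlorine and brings in a methoxy group at once, so the compounds shown cannot separate the loss of chlorine from the arrival of methoxy, and a plain unsubstituted phenyl group at this place would be needed to pull the two apart. Going by these compounds, it also remains open how this place would respond to groups of another kind, such as an amine or a carboxylic acid on the ring.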